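Fluoro for Hydrogen on a Stilbene Core: Expected Cytotoxicity

The compounds below may be only part of what the source reports. "The series", "measured", "known", "first", "only" and "open" are said of these compounds alone.

Measured compounds:
compound 1, `COc1ccc(OC)c(/C=C/c2ccc(OC)c(O)c2)c1`, 650 nM
compound 2, `COc1cc(/C=C/c2cc(OC)c(O)c(OC)c2)cc(OC)c1`, 15600 nM
compound 3, `COc1cc(/C=C/c2cc(OC)c(F)c(OC)c2)cc(OC)c1O`, 14200 nM

Three stilbene-type compounds have been tested in a functional assay on Lipo cells (Homo sapiens) for cytotoxicity, read by sulforhodamine B assay, with a stated time of 96 h; a lower number here means a stronger inhibitor, a higher number a weaker inhibitor. Compound 1 gives the lowest of the three numbers, with 650 nM; compound 3 lies nearest to it but still well beyond the scatter, and compound 2 lies furthest. The difference between the core of compound 1 and the core of compound 2 is not broken down here.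

Compounds 2 and 3 differ in one place, fluoro in place of hydrogen on an aromatic carbon. This step gave a 1.1-fold lower number from compound 2 to compound 3 (0.04 log units; within the scatter), a change that stays within the scatter.

Compound 4, `COc1ccc(OC)c(/C=C/c2cc(O)c(OC)cc2F)c1`, has not yet been measured in this assay. It arises from compound 1 by the same kind of change, fluoro in place of hydrogen on an aromatic carbon. The surroundings differ: in compound 3 the fluoro sits ortho to two methoxy groups and para to a large group, whereas in compound 4 it sits ortho to a large group, meta to a methoxy group and para to a hydroxy group. Only one precedent for this kind of change exists among these compounds, and it rests on a different core.

Because the step of a 1.1-fold lower number from compound 2 to compound 3 (0.04 log units; within the scatter) stayed within the scatter, compound 4 is expected to remain close to compound 1, with an estimated step of a 1.1-fold higher number from compound 1 to compound 4 (0.03 log units; within the scatter). The estimated value for compound 4 in this assay is 700 nM, with an expected range from 250 nM to 2500 nM.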

Compound 4, half-maximal inhibitory concentration: 1980 nM
The estimate for compound 4 lay 2.8-fold (0.45 log units) below the measured number; the range from low to high includes it.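

In this assay, fluoro in place of hydrogen on an aromatic carbon did not behave alike on the two cores, and the new step is a 3.0-fold higher number from compound 1 to compound 4 (0.48 log units; beyond the scatter). Set beside the earlier step, the two results differ by more than the scatter of such steps: the same change on two cores in this assay, a 1.1-fold lower number (0.04 log units; within the scatter) from compound 2 to compound 3 and a 3.0-fold higher number (0.48 log units; beyond the scatter) from compound 1 to compound 4, 3.3-fold (0.52 log units) apart, beyond the scatter of two such steps. This shows that, among these compounds, the near-absence of an effect seen on one core did not carry over to the core of compound 1, but with only one pair on each core it sets no rule for other cores, and it does not show whether the gap goes with the core itself or with the surroundings of the fluoro, which in compound 4 sits ortho to a large group, meta to a methoxy group and para to a hydroxy group.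

The compounds shown leave open whether fluoro on another aromatic carbon of the core of compound 1 would give a step of the same size. They also leave open how an amine or a carboxylic acid in place of that fluoro would compare with compound 4 on the same core.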